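This account rests on a few compounds, and the source may have more. Where it says the series, first, only, none or still open, it means among the compounds named here.

Measured so far in a functional assay on MKN-45 cells (Homo sapiens) for cytotoxicity, read by MTT assay, with a stated time of 72 h; a lower number here means a stronger inhibitor, a higher number a weaker inhibitor:
compound 1 `COc1cc2c(Oc3ccc(NC(=O)c4nn(-c5ccccc5Br)c(=O)c5ccccc45)cc3F)ccnc2cc1OCCCN1CCN(C)CC1` gives 400 nM
compound 2 `COc1cc2c(Oc3ccc(NC(=O)c4nn(-c5ccc([N+](=O)[O-])cc5)c(=O)c5ccccc45)cc3F)ccnc2cc1OCCCN1CCN(C)CC1` gives 1320 nM
compound 3 `COc1cc2c(Oc3ccc(NC(=O)c4nn(-c5ccccc5Br)c(=O)c5ccccc45)cc3F)ccnc2cc1OCCCN1CCC(C)CC1` gives 510 nM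

Compound 4 `COc1cc2c(Oc3ccc(NC(=O)c4nn(-c5ccc([N+](=O)[O-])cc5)c(=O)c5ccccc45)cc3F)ccnc2cc1OCCCN1CCC(C)CC1` is not yet measured. It differs from compound 3 by 4-nitrophenyl in place of 2-bromophenyl on an aromatic nitrogen. The same change is already seen once, from compound 1 to compound 2, where it is 4-nitrophenyl in place of 2-bromophenyl on an aromatic nitrogen and gave a 3.3-fold higher number from compound 1 to compound 2 (0.52 log units; beyond the scatter). The two cores differ by 4-methylpiperidin-1-yl in place of 4-methylpiperazin-1-yl on a saturated chain carbon, three bonds along the chain from an oxygen on an aromatic ring, a change that gave a 1.3-fold higher number from compound 1 to compound 3 (0.11 log units; within the scatter), so compound 3 and compound 1 sit within the usual scatter of each other.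

Going by the values given here, with only one prior instance of the change, the step from compound 3 to compound 4 is expected to be about a 3.3-fold higher number from compound 3 to compound 4 (0.52 log units; beyond the scatter), resting on the earlier step of a 3.3-fold higher number from compound 1 to compound 2 (0.52 log units; beyond the scatter) and on the value of compound 3 510 nM. Compound 4 is therefore estimated at 1700 nM in this assay, with a likely range from 800 nM to 3600 nM.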

Compound 4, half-maximal inhibitory concentration: 1150 nM
For compound 4 the middle estimate is 1.5-fold (0.17 log units) above the measured one; the range from low to high includes it.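

In this assay, 4-nitrophenyl in place of 2-bromophenyl gives a 2.3-fold higher number from compound 3 to compound 4 (0.35 log units; beyond the scatter), and the step carries over between the two cores: the same change on two cores in this assay, a 3.3-fold higher number (0.52 log units; beyond the scatter) from compound 1 to compound 2 and a 2.3-fold higher number (0.35 log units; beyond the scatter) from compound 3 to compound 4, 1.5-fold (0.17 log units) apart, within the scatter of two such steps. 4-Methylpiperidin-1-yl in place of 4-methylpiperazin-1-yl gives a 1.1-fold lower number from compound 2 to compound 4 (0.06 log units; within the scatter), and this change stays within the scatter with either aromatic group: the same change on two cores in this assay, a 1.3-fold higher number (0.11 log units; within the scatter) from compound 1 to compound 3 and a 1.1-fold lower number (0.06 log units; within the scatter) from compound 2 to compound 4, 1.5-fold (0.17 log units) apart, within the scatter of two such steps. This shows that the two changes behave consistently across these four compounds, but it does not show why, or that this holds for other groups or cores.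

Still open, as far as these compounds go, is whether the step follows the group or its position, which 2-nitrophenyl or 4-bromophenyl would separate. Also open, from the compounds shown here alone, is how an unsubstituted phenyl on the aromatic nitrogen or a morpholine at the chain end would fit.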